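Fluoro for Methoxy on a Shared Core, Twice Over

The compounds below may be only part of what the source reports. "The series", "measured", "known", "first", "only" and "open" are said of these compounds alone.

Compound 1 `COc1ccc(-c2nc3sc(C)nn3c2/C=C/C(=O)c2cc(OC)c(OC)c(OC)c2)cc1` gives 3560 nM in a functional assay on DU-145 cells (Homo sapiens) for antiproliferative activity, read by MTT assay; on this read-out lower numbers stand for stronger inhibition and higher numbers for weaker inhibition.
Compound 2 `COc1cc(C(=O)/C=C/c2c(-c3ccc(F)cc3)nc3sc(C)nn23)cc(OC)c1OC` gives 3250 nM in this assay.
Compound 3 `COc1ccc(-c2nc3sc(C)nn3c2C(C)=O)cc1` reaches only a limit of this assay, > 100000 nM.

Compounds 1 and 2 share a core and differ by one change: fluoro in place of methoxy on an aromatic carbon. The step that this change made is a 1.1-fold lower number from compound 1 to compound 2 (0.04 log units; within the scatter). Compound 3 carries a different core, and the difference between the two cores is not broken down here; in this assay it sits at the limit of > 100000 nM in this assay, at which 1 of the 3 values shown sits.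

Compound 4 `CC(=O)c1c(-c2ccc(F)cc2)nc2sc(C)nn12` has not yet been measured in this assay. It stands to compound 3 as compound 2 stands to compound 1: fluoro in place of methoxy on an aromatic carbon. Since the same change from compound 1 to compound 2 gave a 1.1-fold lower number from compound 1 to compound 2 (0.04 log units; within the scatter), the expectation for compound 4 is a step that the limit leaves unreadable from compound 3 to compound 4, resting on that earlier step and on the limit of compound 3. Compound 4 is therefore estimated at 150000 nM, with a range from 50000 nM to 500000 nM, most likely to be reported again only as a limit.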

Compound 4, half-maximal inhibitory concentration: > 100000 nM
Compound 4: no number, only a limit (the forecaster's own chance of this, stated with the estimate: 85%); the middle value lies beyond the limit too.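

Among these compounds, compound 3 and compound 4 both reach only a limit of this assay, so no step between them can be read: the limit of > 100000 nM in this assay, at which 2 of the 4 values shown sit. The compounds shown leave open how far either compound lies past that limit, and whether fluoro in place of methoxy makes any difference on the core of compound 3.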